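The source may hold more compounds than are shown below. What is called first, only, known or untested is meant among the compounds shown, and "the series" means these compounds.

Measured so far in an ADME assay on BJ cells (Homo sapiens), read by MTT assay, with a stated time of 72 h; a higher number here means a weaker inhibitor, a lower number a stronger inhibitor:
- compound 1, `O=c1[nH]cnc2c1c(-c1ccoc1)cn2[C@@H]1O[C@H](CO)[C@@H](O)[C@H]1O`: compound 1 gives > 100000 nM
- compound 2, `COc1nc(N)nc2c1c(-c1ccccc1)cn2[C@@H]1O[C@H](CO)[C@@H](O)[C@H]1O`: compound 2 gives > 100000 nM

Compound 1 stands at a limit of this assay and not at a number: the limit of > 100000 nM in this assay, at which 2 of the 2 values shown sit. Compound 2 also sits at that same limit, so the numbers shown do not separate the two, and no step between measured compounds can be taken from them. Within the data shown here, the series therefore offers no measured step on which to rest a direction.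

Compound 3, `O=c1[nH]cnc2c1c(-c1ccco1)cn2[C@@H]1O[C@H](CO)[C@@H](O)[C@H]1O`, differs from compound 1 in one place: furan-2-yl in place of furan-3-yl on an aromatic carbon. Among the measured compounds shown here, with compound 1 at the limit and no measured step available, the expectation for the step in this assay from compound 1 to compound 3 is none beyond the scatter, that is a number no higher from compound 1 to compound 3 (the limit leaves the size open). Compound 3 is accordingly expected to give about 100000 nM in this assay, within a range of 30000 nM to 300000 nM, most likely reported again only as a limit.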

Compound 3, half-maximal inhibitory concentration: > 100000 nM
Compound 3 was reported as a limit; the forecaster's own chance of this, stated with the estimate: 85%; the middle value lies on the limit itself.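

No step from compound 1 to compound 3 can be read in this assay, since both values are limits and not numbers: the limit of > 100000 nM in this assay, at which 3 of the 3 values shown sit.

The compounds shown leave open how far past that limit each lies, and so whether furan-2-yl in place of furan-3-yl shifts the value in this assay at all.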